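The source may report more compounds than this note shows. Statements on the series, on what has been measured and on what is new or still open speak of the compounds shown alone.

Measured in a functional assay on LoVo cells (Homo sapiens) for inhibition, read by MTT assay, with a stated time of 48 h; on this read-out higher numbers stand for weaker inhibition and lower numbers for stronger inhibition:
Compound 1 `COc1ccc(N(C)c2nc(C)nc3ccccc23)cc1OCCCCCC[Se]C#N`: 8580 nM
Compound 2 `COc1ccc(N(C)c2nc(C)nc3ccccc23)cc1C(=O)NCC[Se]C#N`: 561 nM
Compound 3 `COc1ccc(N(C)c2nc(C)nc3ccccc23)cc1`: 8 nM

Compound 2 holds the middle of these three numbers, reached by a 15-fold lower number from compound 1 to compound 2 (1.18 log units; beyond the scatter) and left by a 70-fold lower number from compound 2 to compound 3 (1.85 log units; beyond the scatter). Compound 4 `COc1ccc(N(C)c2nc(C)nc3ccccc23)cc1C(=O)OCCCCCC[Se]C#N` keeps the carbonyl of compound 2 and changes what it carries: a group of 10 heavy atoms (7 carbon, 1 nitrogen, 1 oxygen, 1 selenium; no ring) in place of a group of 6 heavy atoms (3 carbon, 2 nitrogen, 1 selenium; no ring), on a carbonyl carbon. The closest evidence is compound 1, which has a group of the same count on an aromatic carbon and reads 8580 nM. That group's attachment differs, so only part of a 15-fold lower number from compound 1 to compound 2 (1.18 log units; beyond the scatter) is expected to carry over, as a large step to a higher number in this assay. For compound 4 the estimate is 2500 nM, with an expected range of 600 nM to 9000 nM. The expected change is a 4.5-fold higher number from compound 2 to compound 4 (0.65 log units; beyond the scatter).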

Compound 4, half-maximal inhibitory concentration: 1050 nM
Compound 4: the middle estimate sits 2.4-fold (0.38 log units) above what was measured; the measured number falls inside the stated range.
By their numbers in this assay, from the lowest: compound 3; then compounds 2 and 4 (each within the scatter of the next); then compound 1.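

On a carbonyl carbon, the group of 10 heavy atoms, with 0 hydrogen-bond donors, takes the place of the group of 6 heavy atoms, with 1 donor, and gives a 1.9-fold higher number from compound 2 to compound 4 (0.27 log units; within the scatter) in this assay. Unlike the earlier steps, all beyond the scatter, this exchange leaves the reading unresolved, even though the amide hydrogen goes and the group grows. Nothing measured here explains this result.

The exchange alters the linking atom and the chain together, so their shares cannot be separated. An ester bearing the chain of compound 2, an amide bearing the chain of compound 4, or a free carboxylic acid at this carbonyl would address that.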